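Swapping the indolyl ketone for a dimethoxyphenyl ketone

The compounds below may be only part of what the source reports. "The series", "measured", "known", "first", "only" and "open" are said of these compounds alone.

Of the compounds shown here, two have been tested so far in a functional assay on HCT-116 cells (Homo sapiens) for inhibition, read by sulforhodamine B assay, with a stated time of 72 h; on this read-out higher numbers stand for weaker inhibition and lower numbers for stronger inhibition. Compound 1 `COc1cc(C(=O)/C=C/c2cn(-c3ccccc3)nc2-c2ccsc2)cc(OC)c1OC` gives 3200 nM. Compound 2 `O=C(/C=C/c1cn(-c2ccccc2)nc1-c1cccnc1)c1c[nH]c2ccccc12` gives 6400 nM, the highest of the two numbers; the gap to compound 1 lies within the scatter, so the two cannot be told apart on these data. Compound 3 `COc1ccc(C(=O)/C=C/c2cn(-c3ccccc3)nc2-c2cccnc2)c(OC)c1` has not been measured. It differs from compound 2 in one place: 2,4-dimethoxyphenyl in place of 1H-indol-3-yl on a carbonyl carbon. Going by the values given here, no pair of measured compounds shows this change, so its effect is unknown. The closest guide is compound 1, whose methoxylated aryl ketone gives 3200 nM, a value that sits near compound 2. Compound 3 is therefore expected to land in the same region, with an expected step of a 1.4-fold lower number from compound 2 to compound 3 (0.15 log units; within the scatter) that stays within the scatter, and a predicted value of 4500 nM, ranging from 1500 nM to 13000 nM.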

Compound 3, half-maximal inhibitory concentration: 1300 nM
The estimate for compound 3 lay 3.5-fold (0.54 log units) above the measured number; the whole stated range lies above it.
By their numbers in this assay, from the lowest: compound 3; then compounds 1 and 2 (each within the scatter of the next).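

In this assay, going by these compounds alone, placing 2,4-dimethoxyphenyl instead of 1H-indol-3-yl on the carbonyl carbon gives a 4.9-fold lower number from compound 2 to compound 3 (0.69 log units; beyond the scatter), the first single-place step and one that lies beyond the scatter. It shows that the group on this carbonyl carbon affects the read-out and that 1H-indol-3-yl is not required for inhibition here. Nothing measured explains the gain, since the swap changes the ring system, the hydrogen-bond donor and the hydrogen-bond acceptors all at once, and no supporting data bear on it.

The compounds shown leave open whether a single methoxy group, a plain phenyl or a dimethylamino group on the aryl ketone would give a similar step. They also leave open whether the same change would have a similar effect on a different core.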